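This account rests on a few compounds, and the source may have more. Where it says the series, first, only, none or still open, it means among the compounds named here.

Going by the values given here, compound 3 `CCN(CC)c1nc(Nc2cccc(Cl)c2)nc(OCC(F)(F)C(F)F)n1` gives 5400 nM in an assay on cells for activation of Cystic fibrosis transmembrane conductance regulator (Homo sapiens), read by fluorescence, with stated times of 10 min and 12 s (a lower number here means that less compound is needed, a higher number that more compound is needed for the effect), the highest of the three numbers so far. Compound 2 `CCN(CC)c1nc(Nc2ccccc2)nc(OCC(F)(F)C(F)F)n1` gives 2000 nM, and compound 1 `CCN(CC)c1nc(Nc2ccc(F)cc2)nc(OC(C(F)(F)F)C(F)(F)F)n1` gives 700 nM. Among the compounds with values here, the one measured step that touches the aromatic ring on the nitrogen is the change from compound 2 to compound 3, a 2.7-fold higher number from compound 2 to compound 3 (0.43 log units; beyond the scatter). Compound 4 `CCN(CC)c1nc(Nc2ccc(F)cc2)nc(OCC(F)(F)C(F)F)n1` differs from compound 3 by 4-fluorophenyl in place of 3-chlorophenyl on a nitrogen on an aromatic ring. Within the data shown here, it carries the same ring on the nitrogen as compound 1 and the same remaining structure as compound 2, but no measured step joins compound 1 to compound 2, so their values show only that both stand below compound 3. Removing the chloro is expected to reverse that rise, so compound 4 is estimated near 1500 nM, with a range from 500 nM to 5000 nM, which would mean an expected step of a 3.6-fold lower number from compound 3 to compound 4 (0.56 log units; beyond the scatter).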

Compound 4, half-maximal effective concentration: 4800 nM
For compound 4 the middle estimate is 3.2-fold (0.51 log units) below the measured one; the range from low to high includes it.
By their numbers in this assay, from the lowest: compound 1; then compound 2; then compounds 4 and 3 (each within the scatter of the next).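

On the aromatic ring carried by the nitrogen, swapping 3-chlorophenyl for 4-fluorophenyl gives a 1.1-fold lower number from compound 3 to compound 4 (0.05 log units; within the scatter) and so separates the two groups no further. Fluoro in place of hydrogen gives a 2.4-fold higher number from compound 2 to compound 4 (0.38 log units; beyond the scatter) as its result, a rise like that seen with chloro, so the plain phenyl ring of compound 2 keeps the lower number. The group on the oxygen matters more here, with 2,2,3,3-tetrafluoropropyl in place of 2,2,2-trifluoro-1-(trifluoromethyl)ethyl giving a 6.9-fold higher number from compound 1 to compound 4 (0.84 log units; beyond the scatter) as its step. On these data alone, whether an amine or a methoxy group on the ring would lower the number remains open. Nothing available explains these shifts.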